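The source may hold more compounds than are shown below. What is called first, only, known or untested is meant among the compounds shown, and "the series" means these compounds.

Of the compounds shown here, three have been tested in an ADME assay on HUVEC cells (Homo sapiens) for cytotoxicity, read by MTT assay, with a stated time of 48 h; a lower number here means a stronger inhibitor, a higher number a weaker inhibitor. Compound 1, with the structure `Cc1ccc(NC(=S)OCCNC(=O)C(C)(C)Oc2ccc(Cl)cc2)cc1`, gives 661000 nM in this assay. Compound 2, with the structure `O=C(Oc1ccc(-c2cc(=S)ss2)cc1)c1cccnc1`, gives 562000 nM. Compound 3, with the structure `O=C(NCCOC(=S)Nc1ccccc1)c1cccnc1`, gives 724000 nM. Of these three numbers, compound 3 has the highest, but its nearest neighbour is compound 1 and its furthest is compound 2, and both gaps fall within the usual scatter of repeated measurements, so the three compounds cannot be told apart on what has been measured.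

The next compound to be measured is compound 4, with the structure `COc1ccc(NC(=S)OCCNC(=O)c2cccnc2)cc1`. It differs from compound 3 in one place: methoxy in place of hydrogen on an aromatic carbon. The aromatic carbon that carries the new group sits on a six-membered aromatic ring of carbon only.

Going by the values given here, no pair of measured compounds differing in one place is available, so there is nothing to show what such a change does in this assay. With all three measured numbers so close together, the step from compound 3 to compound 4 is expected to be small and to stay within the scatter, with no clear direction. The expected step is a 1.0-fold lower number from compound 3 to compound 4 (0.01 log units; within the scatter). Compound 4 is therefore estimated at 700000 nM, in a range from 350000 nM to 1400000 nM.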

Compound 4, half-maximal inhibitory concentration: 550000 nM
Compound 4: the middle estimate sits 1.3-fold (0.10 log units) above what was measured; measured number inside the range.
By their numbers in this assay, from the lowest: compounds 4, 2, 1 and 3 (each within the scatter of the next).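

Going by these compounds alone, compounds 3 and 4 form the first pair in this set that differs in one place, so a single change can now be read directly in this assay: methoxy in place of hydrogen on an aromatic carbon, para to a large group, gives a 1.3-fold lower number from compound 3 to compound 4 (0.12 log units; within the scatter). This step lies within the scatter, so at this position the two compounds cannot be told apart, and a methoxy group of this size on this carbon leaves the read-out indistinguishable from that of the unsubstituted compound. Nothing available bears on why the result came out this way.

The compounds shown leave open whether a different group on the same aromatic carbon, such as an amine, a carboxylic acid or a longer alkoxy chain, would produce a step beyond the scatter. They also leave open whether methoxy would behave the same way at another place on this ring or on a different core, as this single pair speaks only for one position on one core.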